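Piperazine demethylation from compound 3 to compound 4

The source may report more compounds than this note shows. Statements on the series, on what has been measured and on what is new or still open speak of the compounds shown alone.

Compound 1 `O=C1N=C(Nc2ccccc2)S/C1=C/c1ccc(N2CCNCC2)cc1`: > 100000 nM
Compound 2 `CN(C)c1ccc(/C=C2/SC(N(c3ccccc3)c3ccccc3)=NC2=O)cc1`: > 100000 nM
Compound 3 `CN1CCN(c2ccc(/C=C3/SC(N(c4ccccc4)c4ccccc4)=NC3=O)cc2)CC1`: > 100000 nM

In an ADME assay on cells (Homo sapiens) for cytotoxicity, read by sulforhodamine B assay, with a stated time of 48 h (on this read-out higher numbers stand for an effect only at larger amounts of compound and lower numbers for an effect already at smaller amounts), compound 1 gives > 100000 nM, which is a limit of the assay and not a number. Compound 2 gives > 100000 nM, again a limit. Compound 3 gives > 100000 nM, also a limit. Among the compounds with values here, the only pair that differs in one place is compound 2 and compound 3, where a step that the two limits leave unreadable from compound 2 to compound 3, since both values are limits. Every value shown so far sits at the limit of > 100000 nM in this assay, at which 3 of the 3 values shown sit, so compound 3 stands at that limit together with the other two, and no ordering among them can be read.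

Compound 4 `O=C1N=C(N(c2ccccc2)c2ccccc2)S/C1=C/c1ccc(N2CCNCC2)cc1` differs from compound 3 by hydrogen in place of methyl on an amine nitrogen in a ring. Compound 1 already carries the piperazin-1-yl group and sits at the same limit, so nothing in the data points to a readable change. Compound 4 is therefore expected to remain at the limit, meaning a step that the limit leaves unreadable from compound 3 to compound 4 is expected to be none beyond the scatter. The estimate for compound 4 is 150000 nM, with a range from 100000 nM to 400000 nM.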

Compound 4, half-maximal effective concentration: > 100000 nM
Compound 4: no number, only a limit; the forecaster's own chance of this, stated with the estimate: 90%; the middle value lies beyond the limit too.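

In this assay compound 4 gives > 100000 nM, which is a limit and not a number. The steps to compound 4 from compound 1, compound 2 and compound 3 therefore cannot be read: the limit of > 100000 nM in this assay, at which 4 of the 4 values shown sit.

The compounds shown leave open whether any of these changes alters the result in this assay at all.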